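Cathepsin K inhibitors: pyrazole amide attachment and ring substituent

The compounds below may be only part of what the source reports. "The series", "measured", "known", "first", "only" and "open" are said of these compounds alone.

Measured compounds:
Compound 1 `CCCC[C@H](NC(=O)OC(C(C)C)C(C)C)C(=O)C(=O)Nc1cc(-c2ccccc2)[nH]n1` gives 12 nM in an assay on isolated protein for inhibition of cathepsin K (Rattus norvegicus); on this read-out higher numbers stand for weaker inhibition and lower numbers for stronger inhibition.
Compound 2 `CCCC[C@H](NC(=O)OC(C(C)C)C(C)C)C(=O)C(=O)Nc1ccnn1C` gives 1700 nM in this assay.
Compound 3 `CCCC[C@H](NC(=O)OC(C(C)C)C(C)C)C(=O)C(=O)Nc1ccn(C)n1` gives 11 nM in this assay.

Compound 3 holds the lowest number of the three; compound 1 sits within the scatter of it, while compound 2 lies far above it. Compound 4 `CCCC[C@H](NC(=O)OC(C(C)C)C(C)C)C(=O)C(=O)Nc1ccnn1C1CCC1` differs from compound 3 by 1-cyclobutyl-1H-pyrazol-5-yl in place of 1-methyl-1H-pyrazol-3-yl on an amide-type nitrogen. Within the data shown here, the one step that bears on this is a 150-fold lower number from compound 2 to compound 3 (2.19 log units; beyond the scatter), which moved the amide-type nitrogen from the 1-methyl-1H-pyrazol-5-yl attachment of compound 2 to the 1-methyl-1H-pyrazol-3-yl attachment of compound 3. Among the measured compounds shown here, compound 4 returns to a pyrazol-5-yl attachment; no measured pair covers methyl against cyclobutyl on that ring nitrogen. A large rise, roughly undoing that step, is therefore expected: an 82-fold higher number from compound 3 to compound 4 (1.91 log units; beyond the scatter). Compound 4 is estimated at 900 nM, with a range of 150 nM to 5000 nM.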

Compound 4, half-maximal inhibitory concentration: 1100 nM
Compound 4: middle estimate off by 1.2-fold (0.09 log units), on the low side; the measured number falls inside the stated range.
By their numbers in this assay, from the lowest: compounds 3 and 1 (each within the scatter of the next); then compounds 4 and 2 (each within the scatter of the next).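

In this assay, 1-cyclobutyl-1H-pyrazol-5-yl in place of 1-methyl-1H-pyrazol-3-yl gives a 100-fold higher number from compound 3 to compound 4 (2.00 log units; beyond the scatter), a step about as large as the one seen between the two methyl isomers. With the pyrazol-5-yl attachment kept, cyclobutyl in place of methyl on the aromatic nitrogen stays within the scatter, with a 1.5-fold lower number from compound 2 to compound 4 (0.19 log units; within the scatter), so the high number holds with both groups. Nothing available explains the penalty of this attachment.

Open, from the compounds shown here alone, is whether 1-cyclobutyl-1H-pyrazol-3-yl would keep the low number of compound 3. Also open, going by these compounds, is how a longer chain or an amine on the ring nitrogen would read.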